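Swapping Cyclohexyl for Benzyl on the Ring Nitrogen

This account rests on a few compounds, and the source may have more. Where it says the series, first, only, none or still open, it means among the compounds named here.

compound 1 `c1ccc2c(-c3cn4ccnc4c(-c4ccc5ncn(C6CCCCC6)c5c4)n3)cccc2c1` 19.3%
compound 2 `Clc1ccc(-c2cn3ccnc3c(-c3ccc4ncn(C5CCCCC5)c4c3)n2)cc1` 19.8%
compound 3 `COc1ccccc1-c1cn2ccnc2c(-c2ccc3ncn(C4CCCCC4)c3c2)n1` 22.2%

In a functional assay on NCI-H522 cells (Homo sapiens) for inhibition, read by sulforhodamine B assay, with a stated time of 48 h, tested at 10 uM (a lower number here means less inhibition, a higher number more inhibition at the concentration tested (going by the name of the read-out)), compound 1 gives 19.3%, the smallest of the three numbers, yet its steps to the others, a number 0.5 percentage points higher from compound 1 to compound 2 (within the scatter) and a number 2.9 percentage points higher from compound 1 to compound 3 (within the scatter), both stay within the scatter, as does a number 2.4 percentage points higher from compound 2 to compound 3 (within the scatter). The three compounds thus read as one level. Compound 4 `c1ccc(Cn2cnc3ccc(-c4nc(-c5cccc6ccccc56)cn5ccnc45)cc32)cc1` differs from compound 1 in one place: benzyl in place of cyclohexyl on an aromatic nitrogen. Among the measured compounds shown here, every measured step alters the aryl group on an aromatic carbon; none touches the ring nitrogen, so no measured step bears on this change. The expected step for compound 4 is therefore a number 0.7 percentage points higher from compound 1 to compound 4 (within the scatter), none beyond the scatter, with a wide range. Compound 4 is estimated at 20%, between 5% and 40%.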

Compound 4, a percentage reported as inhibition, at one concentration (the size of the read-out at that concentration, not a potency): 29.3%
The estimate for compound 4 lay 9.3 percentage points below the measured number; low and high end bracket the measured number.
By their numbers in this assay, from the lowest: compounds 1, 2, 3 and 4 (each within the scatter of the next).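

Among the compounds shown here, the first measured change at the ring nitrogen gives a number 10 percentage points higher from compound 1 to compound 4 (within the scatter) in this assay. Benzyl, with its six-membered aromatic ring, therefore cannot be told apart from cyclohexyl, with its non-aromatic ring, at this position on the core of compound 1. Nothing available here offers an explanation for this reading.

From the compounds shown here alone, whether an aminoethyl chain or a longer alkyl chain on the ring nitrogen would read differently stays open. So does whether benzyl gives a similar reading alongside 4-chlorophenyl or 2-methoxyphenyl.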